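A few compounds are considered here, and "the series" means these few. Any claim that something is new, unique, unknown or untested is made for them only; others in the source may bear on it.

Values in a functional assay on A549 cells (Homo sapiens) for cytotoxicity, read by MTT assay, with a stated time of 72 h (on this read-out lower numbers stand for stronger inhibition and higher numbers for weaker inhibition), for the measured compounds:

compound 1, `COc1ccc(S(=O)(=O)c2nc3ccccc3nc2Nc2cc(OC)cc(OC)c2)cc1`: 12700 nM
compound 2, `COc1ccc(S(=O)(=O)c2nc3ccccc3nc2Nc2ccc(N)cc2)cc1`: 2990 nM
compound 3, `COc1cc(Nc2nc3ccccc3nc2S(=O)(=O)c2ccc(Br)cc2)cc(OC)c1`: 15900 nM

From compound 1 to compound 2 the change is 4-aminophenyl in place of 3,5-dimethoxyphenyl on a nitrogen on an aromatic ring and the step is a 4.2-fold lower number from compound 1 to compound 2 (0.63 log units; beyond the scatter). The cores of compound 1 and compound 3 differ by bromo in place of methoxy on an aromatic carbon, and the step is a 1.3-fold higher number from compound 1 to compound 3 (0.10 log units; within the scatter), so the two cores behave alike in this assay.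

Compound 4, `Nc1ccc(Nc2nc3ccccc3nc2S(=O)(=O)c2ccc(Br)cc2)cc1`, differs from compound 3 by 4-aminophenyl in place of 3,5-dimethoxyphenyl on a nitrogen on an aromatic ring. The place is the same as for the change from compound 1 to compound 2, so it is the same change on the other core. The earlier step is a 4.2-fold lower number from compound 1 to compound 2 (0.63 log units; beyond the scatter). A step of that size is therefore expected here too, that is a 4.2-fold lower number from compound 3 to compound 4 (0.62 log units; beyond the scatter), resting on compound 3 at 15900 nM. Compound 4 is estimated at 3800 nM, between 1500 nM and 9500 nM.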

Compound 4, half-maximal inhibitory concentration: 1020 nM
For compound 4 the middle estimate is 3.7-fold (0.57 log units) above the measured one; measured number below the stated range.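

On both cores in this assay, 4-aminophenyl in place of 3,5-dimethoxyphenyl gives a lower number, but the size of the step does not carry over, with a 16-fold lower number from compound 3 to compound 4 (1.19 log units; beyond the scatter) set against the earlier step: the same change on two cores in this assay, a 4.2-fold lower number (0.63 log units; beyond the scatter) from compound 1 to compound 2 and a 16-fold lower number (1.19 log units; beyond the scatter) from compound 3 to compound 4, 3.7-fold (0.56 log units) apart, beyond the scatter of two such steps.

The same non-additivity appears when bromo replaces methoxy on the 4-aminophenyl compounds, with a 2.9-fold lower number from compound 2 to compound 4 (0.47 log units; beyond the scatter) set against the step on the 3,5-dimethoxyphenyl compounds: the same change on two cores in this assay, a 1.3-fold higher number (0.10 log units; within the scatter) from compound 1 to compound 3 and a 2.9-fold lower number (0.47 log units; beyond the scatter) from compound 2 to compound 4, 3.7-fold (0.56 log units) apart, beyond the scatter of two such steps.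

The direction of the nitrogen change therefore carries across these two cores, while its size does not, and a single pair of pairs shows neither the cause nor how general this is.

Still open, from the compounds shown here alone, is whether the larger step on the bromo core recurs with other nitrogen substituents, such as 4-hydroxyphenyl. Going by these compounds, it is equally open whether chloro or trifluoromethyl in place of bromo would behave the same way.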